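Swapping the Triazole Aryl on a Compound at the Limit

A few compounds are considered here, and "the series" means these few. Any claim that something is new, unique, unknown or untested is made for them only; others in the source may bear on it.

Compound 1 `C=C1C[C@]23C[C@@]1(O)CC[C@H]2c1ccc(O)c(C)c1[C@@H]3Cn1cc(-c2ccccn2)nn1` carries a pyridin-2-yl group on a five-membered aromatic ring with three nitrogens attached to the shared core. In a functional assay on HL-60 cells (Homo sapiens) for cytotoxicity, read by MTT assay, with a stated time of 4 days (on this read-out higher numbers stand for weaker inhibition and lower numbers for stronger inhibition), compound 1 gives only a limit of the assay, > 20000 nM. Compound 3 `C=C1C[C@]23C[C@@]1(O)CC[C@H]2c1cc(Br)c(O)c(C)c1[C@@H]3Cn1cc(-c2ccccn2)nn1` differs from it by bromo in place of hydrogen on an aromatic carbon, and in this assay compound 3 likewise gives a limit, > 20000 nM. The step that the two limits leave unreadable from compound 1 to compound 3 therefore cannot be read. Compound 2 `Cc1ccc(S(=O)(=O)Oc2ccc3c(c2C)[C@H](Cn2cc(-c4ccccn4)nn2)[C@@]24CC(=O)[C@@](C)(CC[C@@H]32)C4)cc1` in this assay also gives a limit, > 20000 nM. All three values sit at the same point, (the limit of > 20000 nM in this assay, at which 3 of the 3 values shown sit), so compound 1 stands nowhere in particular among them: none of the three shows a number.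

Compound 4 `C=C1C[C@]23C[C@@]1(O)CC[C@H]2c1ccc(O)c(C)c1[C@@H]3Cn1cc(-c2ccc(F)cc2)nn1` arises from compound 1 by 4-fluorophenyl in place of pyridin-2-yl on an aromatic carbon. For the measured compounds named here, no measured step bears on this exchange, and the only measured step is unreadable. With nothing pointing the other way, compound 4 is expected to stay at the limit as well, estimated at 25000 nM with a range from 8000 nM to 80000 nM. The step that the limit leaves unreadable from compound 1 to compound 4 is thus expected to show no readable change from compound 1.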

Compound 4, half-maximal inhibitory concentration: > 20000 nM
Compound 4: only a limit was reported; the forecaster's own chance of this, stated with the estimate: 80%; the middle value does not contradict the limit.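

In this assay compound 4 gives > 20000 nM, again a limit and not a number, so its step from compound 1 cannot be read: the limit of > 20000 nM in this assay, at which 4 of the 4 values shown sit.

The compounds shown leave open whether pyridin-2-yl and 4-fluorophenyl differ at all in this assay.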